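The source may hold more compounds than are shown below. What is called first, only, known or untested is meant among the compounds shown, and "the series" means these compounds.

Working notes on the series. The shared core carries a saturated chain ending in a substituted phenyl group. Compound 1 `COC(=O)c1ccccc1CCCCCCC(=O)c1ncc(-c2ccccn2)o1` gives 1 nM in an assay for inhibition of Fatty-acid amide hydrolase 1 (Rattus norvegicus); on this read-out higher numbers stand for weaker inhibition and lower numbers for stronger inhibition; compound 2 `O=C(CCCCCCc1ccccc1Cl)c1ncc(-c2ccccn2)o1` gives 1.9 nM in this assay; compound 3 `Nc1cccc(CCCCCCC(=O)c2ncc(-c3ccccn3)o2)c1` gives 30 nM in this assay. Compound 3 therefore stands highest of the three numbers measured, with compound 2 nearest and compound 1 furthest.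

Compound 4 `CSc1ccccc1CCCCCCC(=O)c1ncc(-c2ccccn2)o1` is not yet measured. The change from compound 3 is 2-(methylsulfanyl)phenyl in place of 3-aminophenyl on a saturated chain carbon, six bonds along the chain from a carbonyl carbon. Within the data shown here, two measured steps bear on it. The step of a 1.9-fold higher number from compound 1 to compound 2 (0.28 log units; within the scatter) shows that exchanging one group for another on the aromatic carbon of a 2-substituted phenyl leaves the number essentially unchanged. The step of a 16-fold higher number from compound 2 to compound 3 (1.20 log units; beyond the scatter) shows that moving to the 3-aminophenyl group raised the number markedly. Returning to a phenyl substituted as in compound 2 is therefore expected to reverse most of that rise, so a large step downward, a 12-fold lower number from compound 3 to compound 4 (1.08 log units; beyond the scatter), is expected in this assay. Compound 4 is accordingly estimated at 2.5 nM in this assay, with a range from 0.8 nM to 8 nM.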

Compound 4, inhibition constant: 3.3 nM
For compound 4 the middle estimate is 1.3-fold (0.12 log units) below the measured one; the measured number falls inside the stated range.
By their numbers in this assay, from the lowest: compounds 1, 2 and 4 (each within the scatter of the next, the first and the last beyond it); then compound 3.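

In this assay, 2-(methylsulfanyl)phenyl in place of 3-aminophenyl on this saturated chain carbon gives a 9.1-fold lower number from compound 3 to compound 4 (0.96 log units; beyond the scatter), so the higher number of compound 3 is not shared by this third substituted phenyl group. Methylsulfanyl in place of chloro on the aromatic carbon gives a 1.7-fold higher number from compound 2 to compound 4 (0.24 log units; within the scatter), so these two groups cannot be told apart here, whereas methylsulfanyl in place of methoxycarbonyl gives a 3.3-fold higher number from compound 1 to compound 4 (0.52 log units; beyond the scatter), a modest step that does separate this pair. The measurements offer no explanation for any of these steps.

The compounds shown leave open whether the higher number of compound 3 goes with the amine itself or with where it sits, since 3-aminophenyl differs from the other groups in both respects. A 2-aminophenyl group would bear directly on that question.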